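The source may hold more compounds than are shown below. What is called first, only, known or untested is meant among the compounds shown, and "the series" means these compounds.

Compound 1 `COc1ccc(-c2c(S(=O)(=O)c3cccc(C#N)c3)cnc3cc(F)ccc23)cc1` is the starting point of this account. In an ADME assay on microsomes from liver (Homo sapiens) for metabolic stability, tested at 2.5 uM (on this read-out lower numbers stand for slow clearance and higher numbers for fast clearance), compound 1 gives 0.92 mL/min, which places it second highest among the three measured numbers. Its nearest neighbour is compound 2 `N#Cc1cccc(S(=O)(=O)c2cnc3cc(F)ccc3c2-c2cccc(Cl)c2)c1`, which gives 0.99 mL/min in this assay; the step of a 1.1-fold higher number from compound 1 to compound 2 (0.03 log units; within the scatter) is within the scatter. The furthest is compound 3 `N#Cc1ccc2c(-c3ccc(Cl)cc3)c(S(=O)(=O)c3ccc(F)cc3)cnc2c1`, which gives 0.01 mL/min in this assay, far below compound 1, though compound 3 differs from compound 1 in more than one place, so no single change can be read from that gap.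

The next compound is compound 4 `COc1ccc(-c2c(S(=O)(=O)c3ccc(F)c(F)c3)cnc3cc(F)ccc23)cc1`, which differs from compound 1 as follows: 3,4-difluorophenyl in place of 3-cyanophenyl on a sulfonyl sulfur. For the measured compounds named here, no measured step touches the group on the sulfonyl sulfur: the only single-point step, a 1.1-fold higher number from compound 1 to compound 2 (0.03 log units; within the scatter), concerns the group on the aromatic carbon and lies within the scatter, and compound 3 carries other changes besides. Going by the values given here, there is therefore no direct precedent in this set for exchanging 3-cyanophenyl for 3,4-difluorophenyl, and the expectation is a step of a 1.2-fold lower number from compound 1 to compound 4 (0.06 log units; within the scatter), that is, no change beyond the scatter. Compound 4 is accordingly estimated at 0.8 mL/min in this assay, with a range from 0.25 mL/min to 2.5 mL/min.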

Compound 4, intrinsic clearance in a liver preparation (reported as CLH), per the amount of preparation that the assay uses: 1.1 mL/min
Beside the measured number, compound 4's estimate is 1.4-fold (0.14 log units) below it; the range from low to high includes it.
By their numbers in this assay, from the lowest: compound 3; then compounds 1, 2 and 4 (each within the scatter of the next).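

For the compounds shown here, compound 4 gives the first single-place reading at the sulfonyl sulfur: in this assay the exchange of 3-cyanophenyl for 3,4-difluorophenyl gives a 1.2-fold higher number from compound 1 to compound 4 (0.08 log units; within the scatter) and so stays within the scatter, although the leaving group carries 1 hydrogen-bond acceptor and a triple bond while the entering group carries neither. Together with the exchange on the aromatic carbon, which gives a 1.1-fold higher number from compound 1 to compound 2 (0.03 log units; within the scatter) in the same read-out, this means that one change at either of these two places has so far left the number within the scatter of compound 1, a statement that rests on these two pairs alone. The data hold nothing that would explain why the two aryl groups on the sulfonyl sulfur read alike.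

Open, from the compounds shown here alone, is whether a group of another kind on the sulfonyl sulfur, such as an amine, a carboxylic acid or a longer chain, would stay equally close to compound 1 or move beyond the scatter. Also open is which of its several differences goes with the far lower number of compound 3 (0.01 mL/min), since no single-place step connects compound 3 to any other compound shown.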